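A few compounds are considered here, and "the series" means these few. Any claim that something is new, unique, unknown or untested is made for them only; others in the source may bear on it.

Of the compounds shown here, two have so far been read in a functional assay on DU-145 cells (Homo sapiens) for cytotoxicity, read by MTT assay, with a stated time of 48 h; on this read-out higher numbers stand for weaker inhibition and lower numbers for stronger inhibition. Compound 1 `COc1ccc(-c2nc3ccccn3c2C(=O)/C=C\Nc2ccc3ncccc3c2)cc1` gives 4720 nM in this test. Compound 2 `O=C(/C=C\Nc1ccc2cc[nH]c2c1)c1c(-c2ccc(Cl)cc2)nc2ccccn12` gives 2630 nM, and these two numbers lie within the usual scatter of each other. For the measured compounds named here, compound 2 therefore stands level with the only other number available, and neither compound can be ranked over the other.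

Compound 3 `O=C(/C=C\Nc1ccc2ncccc2c1)c1c(-c2ccc(Cl)cc2)nc2ccccn12` comes from compound 2 through a single change: quinolin-6-yl in place of 1H-indol-6-yl on an amine nitrogen. In words, quinolin-6-yl takes the place of 1H-indol-6-yl on an amine nitrogen. Going by the values given here, no measured pair differs in just one place, so the data hold no direct precedent for the size of this step. Among the compounds with values here, the only guide is the narrow spread of the readings, with compound 1 at 4720 nM and compound 2 at 2630 nM. On that basis, no step beyond the scatter is expected in this assay, in either direction. The expected change is a 1.1-fold higher number from compound 2 to compound 3 (0.06 log units; within the scatter), which would stay within the scatter. For compound 3 the estimated value is 3000 nM, with an expected range from 1000 nM to 8000 nM.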

Compound 3, half-maximal inhibitory concentration: 13600 nM
Compound 3: middle estimate off by 4.5-fold (0.66 log units), on the low side, outside the stated range (above it).
By their numbers in this assay, from the lowest: compounds 2 and 1 (each within the scatter of the next); then compound 3.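

In this assay, for the compounds shown here, quinolin-6-yl in place of 1H-indol-6-yl on an amine nitrogen gives a 5.2-fold higher number from compound 2 to compound 3 (0.71 log units; beyond the scatter), the first evidence that the group at this position can move the reading beyond the scatter, with the 1H-indol-6-yl form giving the stronger inhibition of the pair. The aromatic carbon carrying chloro or methoxy also matters: with quinolin-6-yl held on the amine nitrogen, chloro in place of methoxy gives a 2.9-fold higher number from compound 1 to compound 3 (0.46 log units; beyond the scatter), so the methoxy form gives the stronger inhibition of that pair. Nothing available explains either step, and the change on the amine nitrogen alters a ring, the hydrogen-bond donor count and the hydrogen-bond acceptor count together, with no way here to tell which of these counts.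

Going by these compounds, it remains open whether the step between 1H-indol-6-yl and quinolin-6-yl keeps its size when methoxy replaces chloro on the aromatic carbon. On these data alone, it is also open how other groups would read at either place, such as a fluoro or a trifluoromethyl on the aromatic carbon, or a simple phenyl on the amine nitrogen.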